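The source may hold more compounds than are shown below. What is called first, only, known or untested is meant among the compounds shown, and "the series" means these compounds.

Measured compounds:
compound 1 `CCN1CCN(c2ccc3oc([C@]4(CN5Cc6ccc(OC)c(F)c6C5=O)NC(=O)N(COC(=O)C(C)(C)C)C4=O)cc3n2)CC1`: 12700 ng.h/mL
compound 2 `COc1ccc2c(c1F)C(=O)N(C[C@@]1(c3cc4nc(N)ccc4o3)NC(=O)N(COC(=O)C(C)(C)C)C1=O)C2`: 216 ng.h/mL

For the measured compounds named here, of the two numbers known in an ADME assay on the whole organism for pharmacokinetics, with Rattus norvegicus as the target, read by LC-MS, at a dose of 10 mg/kg by the oral route (a higher number here means more compound in the circulation at the dose given, a lower number less compound in the circulation), compound 1 holds the higher one. The other belongs to compound 2, and the distance between them is a 59-fold lower number from compound 1 to compound 2 (1.77 log units; beyond the scatter), a change that puts amino in place of the 4-ethylpiperazin-1-yl group on an aromatic carbon. Compound 3 `CCN1CCN(c2ccc3oc([C@]4(CN5Cc6ccc(OC)cc6C5=O)NC(=O)N(COC(=O)C(C)(C)C)C4=O)cc3n2)CC1` keeps that piperazine group and alters a different part of the shared core: hydrogen in place of fluoro on an aromatic carbon. Going by the values given here, the one measured step concerns another position and another kind of group, so it offers no direct guidance on the loss of a single fluorine. Nothing comparable for fluoro is known among these compounds. With no shown step for this change, the expectation for compound 3 in this assay is a number near that of compound 1, within the usual scatter, in no clear direction. The expected step is a 1.2-fold lower number from compound 1 to compound 3 (0.06 log units; within the scatter). Compound 3 is therefore estimated at 11000 ng.h/mL, with a range from 4500 ng.h/mL to 27000 ng.h/mL.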

Compound 3, area under the concentration-time curve: 433 ng.h/mL
For compound 3 the middle estimate is 25-fold (1.40 log units) above the measured one, and the stated range ends above it.
By their numbers in this assay, from the lowest: compounds 2 and 3 (each within the scatter of the next); then compound 1.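

In this assay, the fluoro on the aromatic carbon ortho to a methoxy group proves to matter a great deal: with hydrogen in its place and the rest of the molecule unchanged, there is a 29-fold lower number from compound 1 to compound 3 (1.47 log units; beyond the scatter). Until now, the only large step shown was the exchange of a whole 4-ethylpiperazin-1-yl group for amino, a 59-fold lower number from compound 1 to compound 2 (1.77 log units; beyond the scatter), whereas this equally large-rated step comes from changing a single heavy atom, so a very small edit at this position can decide how much compound reaches the circulation. No measurement shown here explains why the number falls when this fluorine is lost.

The compounds shown leave open whether another small group on this carbon, such as chloro or methyl, would hold the number near that of compound 1, or whether only fluoro does so. They also leave open whether losing the fluoro has a step of similar size when amino stands in place of the 4-ethylpiperazin-1-yl group, since this change has been read only once, on the piperazine-bearing compounds.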